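The source may hold more compounds than are shown below. What is called first, only, known or untested is meant among the compounds shown, and "the series" means these compounds.

Of the compounds shown here, three in a functional assay on the whole organism for inhibition, with Rattus norvegicus as the target, read by paw edema, with a stated time of 30 min, at a dose of 80 mg/kg by the oral route (on this read-out higher numbers stand for a stronger effect at the one dose given and lower numbers for a weaker effect), frame the series so far. Compound 1 `Clc1ccc(OCC2=NCCO2)cc1` gives 94.1%, compound 2 `Brc1ccccc1OCC1=NCCO1` gives 62.8%, and compound 3 `Clc1ccccc1OCC1=NCCO1` gives 45.5%. Compound 3 and compound 2 differ in one place, (bromo in place of chloro on an aromatic carbon), and the step of a number 17.3 percentage points higher from compound 3 to compound 2 (beyond the scatter). Compound 1 and compound 3 have the same atoms joined differently; the difference between the two cores is not broken down here.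

Compound 4 `Brc1ccc(OCC2=NCCO2)cc1` has not yet been measured in this assay. It differs from compound 1 by bromo in place of chloro on an aromatic carbon, the same kind of change as from compound 3 to compound 2, but the place is not the same: here para to a group of 7 heavy atoms, there ortho to a group of 7 heavy atoms. Because compound 1 already stands at 94.1%, little room remains upward, so the step of a number 1.1 percentage points lower from compound 1 to compound 4 (within the scatter) is expected to lie within the scatter. Compound 4 is estimated at 93%, between 82% and 99%.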

Compound 4, a percentage reported as inhibition, in the whole organism at one dose (the size of the read-out at that dose, not a potency): 60.1%
Estimate against measurement, compound 4: 32.9 percentage points above; measured number outside the range, below it.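

In this assay, bromo in place of chloro on an aromatic carbon gives a number 34 percentage points lower from compound 1 to compound 4 (beyond the scatter). Set beside the earlier step, the same change does not carry over from one core to the other, either in size or in direction: the same change on two cores in this assay, a number 17.3 percentage points higher (beyond the scatter) from compound 3 to compound 2 and a number 34 percentage points lower (beyond the scatter) from compound 1 to compound 4, 51.3 percentage points apart, beyond the scatter of two such steps
For the compounds shown here, this rests on only two pairs, which differ both in core and in where the change sits on the ring; the data do not separate these two factors and give no cause for the reversal.

Open, as far as these compounds go, is how fluoro or iodo at either place would compare with chloro and bromo on these cores. Also open, from the compounds shown here alone, is whether a non-halogen group, such as methoxy or an amine, would follow either step.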